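The source may hold more compounds than are shown below. What is called first, only, known or untested is meant among the compounds shown, and "the series" means these compounds.

Measured so far in a functional assay on SMMC-7721 cells (Homo sapiens) for cytotoxicity, read by MTT assay, with a stated time of 4 days; on this read-out lower numbers stand for stronger inhibition and higher numbers for weaker inhibition:
compound 1 `C=C1C[C@]23C[C@@]1(O)CC[C@@H]2c1cccc(C)c1[C@@H]3Cn1cc(-c2ccc(Br)cc2)nn1`, reported only as a limit, > 20000 nM
compound 2 `C=C1C[C@]23C[C@@]1(O)CC[C@H]2c1ccc(OS(=O)(=O)c2ccc(C)cc2)c(C)c1[C@@H]3Cn1cc(-c2ccc(C)cc2)nn1`, reported only as a limit, > 20000 nM
compound 3 `C=C1C[C@]23C[C@@]1(O)CC[C@H]2c1cc(Br)c(O)c(C)c1[C@@H]3Cn1cc(-c2ccccc2)nn1`, reported only as a limit, > 20000 nM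

Compound 1 therefore stands at the limit of this assay, not at a number. The same holds for every value shown: the limit of > 20000 nM in this assay, at which 3 of the 3 values shown sit. Nothing in the series separates compound 1 from compound 2 or compound 3.

Compound 4 `C=C1C[C@]23C[C@@]1(O)CC[C@@H]2c1cccc(C)c1[C@@H]3Cn1cc(-c2ccc(Cl)cc2)nn1` differs from compound 1 in one place: chloro in place of bromo on an aromatic carbon. Among the compounds with values here, no step between measured compounds is available to anchor this change, and the measured values give no direction. For this assay no step beyond the scatter is expected; compound 4 is expected to sit at the limit as well, with a step that the limit leaves unreadable from compound 1 to compound 4 as the estimated step. Compound 4 is estimated at 30000 nM, within 12000 nM to 80000 nM.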

Compound 4, half-maximal inhibitory concentration: > 20000 nM
Compound 4: a limit, no number (the forecaster's own chance of this, stated with the estimate: 80%); the middle value is on the limit's open side.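

Compound 1 and compound 4 are both limits, so no step between them can be read: the limit of > 20000 nM in this assay, at which 4 of the 4 values shown sit.

The compounds shown leave open whether chloro and bromo differ here, and whether any change to the shared core gives a number rather than a limit.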